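Swapping a Sulfonyl Cap for a Cyclohexyl Carbonyl

The source may report more compounds than this note shows. Statements on the series, on what has been measured and on what is new or still open speak of the compounds shown alone.

In an assay on a protein complex for inhibition of integrin alpha-5/beta-1 (Homo sapiens), read by ELISA (on this read-out lower numbers stand for stronger inhibition and higher numbers for weaker inhibition), compound 3 `Cc1cc(C)c(S(=O)(=O)N[C@@H](CNC(=O)CO[C@@H]2C[C@@H](CNc3ccccn3)N(C(=O)OCc3ccccc3)C2)C(=O)O)c(C)c1` gives 3.7 nM. Among the three measured compounds this number stands second highest: compound 1 `Cc1cc(C)c(S(=O)(=O)N[C@@H](CNC(=O)CO[C@@H]2C[C@@H](CNc3ccccn3)N(C(=O)CC(C)(C)C)C2)C(=O)O)c(C)c1` gives 6 nM, a gap within the scatter, while compound 2 `CC(C)(C)CC(=O)N1C[C@H](OCC(=O)NC[C@H](NC(=O)C2(C)CCCCC2)C(=O)O)C[C@H]1CNc1ccccn1` gives 1.4 nM, a gap beyond it. Compound 4 `CC1(C(=O)N[C@@H](CNC(=O)CO[C@@H]2C[C@@H](CNc3ccccn3)N(C(=O)OCc3ccccc3)C2)C(=O)O)CCCCC1` differs from compound 3 in one place: (1-methylcyclohexyl)carbonyl in place of (2,4,6-trimethylphenyl)sulfonyl on an amine nitrogen. The same exchange has been seen once, as a 4.3-fold lower number from compound 1 to compound 2 (0.63 log units; beyond the scatter). The other measured step, a 1.6-fold lower number from compound 1 to compound 3 (0.21 log units; within the scatter), sits at a different position and only sets the background on which the exchange is now made. For compound 4 a step of about that size towards a lower number is therefore expected, a 4.1-fold lower number from compound 3 to compound 4 (0.61 log units; beyond the scatter). Compound 4 is estimated at 0.9 nM, within a range from 0.4 nM to 2 nM.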

Compound 4, half-maximal inhibitory concentration: 1.7 nM
Compound 4: the middle estimate sits 1.9-fold (0.28 log units) below what was measured; the range from low to high includes it.
By their numbers in this assay, from the lowest: compounds 2 and 4 (each within the scatter of the next); then compounds 3 and 1 (each within the scatter of the next).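

On the amine nitrogen, (1-methylcyclohexyl)carbonyl in place of (2,4,6-trimethylphenyl)sulfonyl now also gives a lower number on a second core (a 2.2-fold lower number from compound 3 to compound 4 (0.34 log units; beyond the scatter)). The two readings of this exchange agree within the scatter, so in these two pairs it does not depend on the core: the same change on two cores in this assay, a 4.3-fold lower number (0.63 log units; beyond the scatter) from compound 1 to compound 2 and a 2.2-fold lower number (0.34 log units; beyond the scatter) from compound 3 to compound 4, 2.0-fold (0.29 log units) apart, within the scatter of two such steps. Benzyloxy in place of neopentyl stays within the scatter with the new group as well (a 1.2-fold higher number from compound 2 to compound 4 (0.08 log units; within the scatter)): the same change on two cores in this assay, a 1.6-fold lower number (0.21 log units; within the scatter) from compound 1 to compound 3 and a 1.2-fold higher number (0.08 log units; within the scatter) from compound 2 to compound 4, 2.0-fold (0.29 log units) apart, within the scatter of two such steps.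

The compounds shown leave open whether the methyl on the cyclohexane ring matters. On these data alone, how a plain cyclohexylcarbonyl or a benzoyl group would read on this nitrogen also remains open.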